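The compounds below may be only part of what the source reports. "The series", "measured", "known", "first", "only" and "open" are said of these compounds alone.

Working notes on the series, read throughout in a functional assay on HCT-116 cells (Homo sapiens) for antiproliferative activity, read by MTT assay, with a stated time of 72 h; on this read-out lower numbers stand for stronger inhibition and higher numbers for weaker inhibition. Among the compounds with values here, compound 1 (`C=CS(=O)(=O)Nc1ccc(Cl)c(S(=O)(=O)N(C)C)c1`) gives 9900 nM as the only true number so far, but it differs from compound 2 in more than one place. Compound 2 (`C=CC(=O)N(CC(=O)OCC)c1nc(-c2ccccc2)cs1`) stands only at a limit, > 30000 nM as reported. Compound 3 (`C=CC(=O)N(CC(=O)NC1CCCCC1)c1nc(-c2ccccc2)cs1`) also stands only at a limit, >= 29300 nM as reported.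

Compound 4 (`C=CC(=O)N(Cc1cccnc1)c1nc(-c2ccccc2)cs1`) departs from compound 2 as follows: pyridin-3-yl in place of ethoxycarbonyl on a saturated chain carbon bound to an amide-type nitrogen. Within the data shown here, the one measured step on this side chain is a step that the two limits leave unreadable from compound 2 to compound 3 (cyclohexylamino in place of ethoxy on a carbonyl carbon), so it supplies no size to carry over. No large step is expected in this assay, and any movement can only be expected toward stronger inhibition from a limit of this kind. The expected change is an at least 1.2-fold lower number from compound 2 to compound 4 (0.07 log units; that floor lies within the scatter) (an estimate only). For compound 4 the estimated value is 25000 nM (expected range 7000 nM to 60000 nM), and another limit is about as likely as a number.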

Compound 4, half-maximal inhibitory concentration: > 30000 nM
Compound 4 ended at the assay's limit (the forecaster's own chance of this, stated with the estimate: 55%); middle value at least 1.2-fold (0.07 log units) from the limit.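

Compound 2 and compound 4 both end at a limit in this assay, so no step between them can be read: the limit of > 30000 nM in this assay, at which 2 of the 4 values shown sit.

The compounds shown leave open how far compound 2, compound 3 and compound 4 truly differ, and whether any such side chain on the shared core gives a true number.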